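Oxime and ketone triazole thioethers: allyl for phenyl on ring nitrogen

The compounds below may be only part of what the source reports. "The series", "measured", "known", "first", "only" and "open" are said of these compounds alone.

Compound 1 `COc1ccc(-c2nnc(SC/C(=N/O)c3ccccc3)n2-c2ccccc2)cc1` carries an oxime on its side chain and a 4-methoxyphenyl group on the core. In a functional assay on the whole organism (strain albino) for inhibition, with Rattus norvegicus as the target, read by paw edema, with a stated time of 4 h, at a dose of 0.28 mmol/kg by the oral route (on this read-out lower numbers stand for less inhibition and higher numbers for more inhibition at the one dose given (going by the name of the read-out)), compound 1 gives 80%, the highest of the three numbers. Compound 2 `COc1ccc(-c2nnc(SCC(=O)c3ccccc3)n2-c2ccccc2)cc1OC` has a ketone in the side chain and a 3,4-dimethoxyphenyl group; in this assay compound 2 gives 65%. Compound 3 `C=CCn1c(SCC(=O)c2ccccc2)nnc1-c1ccc(OC)c(OC)c1` is compound 2 with allyl in place of phenyl on the aromatic nitrogen, marked as allyl in place of phenyl on an aromatic nitrogen; in this assay compound 3 gives 72%. The step of a number 7 percentage points higher from compound 2 to compound 3 (within the scatter) is within the scatter, so no direction is read from it. The difference between the core of compound 1 and the core of compound 2 is not broken down here.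

Compound 4 `C=CCn1c(SC/C(=N/O)c2ccccc2)nnc1-c1ccc(OC)cc1` is not yet measured. It arises from compound 1 by allyl in place of phenyl on an aromatic nitrogen, the same kind of change as in compound 3, with a different neighbourhood: here the ring atom next to the place bears a 4-methoxyphenyl group and the other a large group, whereas in compound 3 they bear a (benzoylmethyl)sulfanyl group and a 3,4-dimethoxyphenyl group.

Expected for compound 4 in this assay is a step of a number 2 percentage points higher from compound 1 to compound 4 (within the scatter), resting on compound 1 at 80% and on the earlier step of a number 7 percentage points higher from compound 2 to compound 3 (within the scatter). Compound 4 is therefore estimated at 82%, between 70% and 92%.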

Compound 4, a percentage reported as inhibition, in the whole organism at one dose (the size of the read-out at that dose, not a potency): 76%
Compound 4: the middle estimate sits 6 percentage points above what was measured, within the range that was stated.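

In this assay allyl in place of phenyl on the aromatic nitrogen gives a number 4 percentage points lower from compound 1 to compound 4 (within the scatter) and so leaves no readable effect on the core of compound 1, as on the core of compound 3. Set side by side, the two cases give no sign that the outcome of this change depends on the core: the same change on two cores in this assay, a number 7 percentage points higher (within the scatter) from compound 2 to compound 3 and a number 4 percentage points lower (within the scatter) from compound 1 to compound 4, 11 percentage points apart, within the scatter of two such steps. Within the resolution of this single-dose read-out, phenyl and allyl at this place cannot be told apart on these two cores, but that does not show that the two steps are equal, that the change has no effect, or that the result extends to other cores in the series.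

The compounds shown leave open whether the oxime or ketone side chain and the 4-methoxyphenyl or 3,4-dimethoxyphenyl group matter on their own, as no pair here differs in only one of these features. Also open, from the compounds shown here alone, is what a longer chain or an amine in place of allyl on the ring nitrogen would give, and whether a carboxylic acid in place of the oxime would leave the read-out where it stands.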